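Tetrahydronaphthalenyl in place of phenylcyclohexyl on a nitrile scaffold

The compounds below may be only part of what the source reports. "The series", "measured", "known", "first", "only" and "open" are said of these compounds alone.

Compound 1 `N#C[C@@]1(NC(=O)[C@@H](CC(=O)N2CCOCC2)CC2CCC(c3ccccc3)CC2)CCN(C2CCCCC2)C1` stands highest of the two measured numbers in an assay on isolated protein for inhibition of cathepsin S (Homo sapiens) (on this read-out lower numbers stand for stronger inhibition and higher numbers for weaker inhibition), where compound 1 gives 3140 nM. Compound 2 `N#C[C@@]1(NC(=O)[C@@H](CC(=O)N2CCOCC2)CC2CCCCC2)CCN(C2CCCC2)C1`, which differs from it in two places, gives 75 nM in this assay, a gap beyond the usual scatter. Compound 3 `N#C[C@@]1(NC(=O)[C@@H](CC(=O)N2CCOCC2)CC2CCc3ccccc3C2)CCN(C2CCCCC2)C1` carries 1,2,3,4-tetrahydronaphthalen-2-yl in place of 4-phenylcyclohexyl on a saturated chain carbon, two bonds along the chain from a carbonyl carbon. For the measured compounds named here, no measured pair isolates this single change. The step from compound 1 to compound 3 is expected to be a 3.9-fold lower number from compound 1 to compound 3 (0.59 log units; beyond the scatter), toward a lower number, beyond the scatter. Compound 3 is therefore estimated at 800 nM in this assay, within a range from 150 nM to 4000 nM.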

Compound 3, half-maximal inhibitory concentration: 1.9 nM
For compound 3 the middle estimate is 420-fold (2.62 log units) above the measured one; the measured number lies below the stated range.
By their numbers in this assay, from the lowest: compound 3; then compound 2; then compound 1.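

At the saturated chain carbon, two bonds along the chain from a carbonyl carbon, the choice of group has a very large effect in this assay: 1,2,3,4-tetrahydronaphthalen-2-yl in place of 4-phenylcyclohexyl gives a 1700-fold lower number from compound 1 to compound 3 (3.22 log units; beyond the scatter). Both groups contain the same two ring types, so a change in the number of heavy atoms and a different arrangement of those rings are enough for a step of this size. Nothing measured here explains the step. On these data alone, whether indan-2-yl at this position would give a similarly low number remains open.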